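A few compounds are considered here, and "the series" means these few. Any claim that something is new, unique, unknown or untested is made for them only; others in the source may bear on it.

Compound 1 `COc1cc(-c2cc(/C=C/C(=O)c3ccc(N)cc3)[nH]n2)cc(OC)c1OC` is the reference point of the set. Among the compounds with values here, in a functional assay on SR cells (Homo sapiens) for inhibition, read by sulforhodamine B assay, with a stated time of 48 h (on this read-out higher numbers stand for weaker inhibition of growth and lower numbers for stronger inhibition of growth), compound 1 gives 2750 nM, the lowest of the three numbers so far. Compound 2 `COc1ccc(-c2cc(/C=C/C(=O)c3ccc(OC)c(OC)c3)[nH]n2)cc1` gives 3740 nM, within the scatter of compound 1. Within the data shown here, compound 3 `COc1cc(-c2cc(/C=C/C(=O)c3ccc(Cl)c(Cl)c3)[nH]n2)cc(OC)c1OC` gives 13500 nM; the one single-point step, a 4.9-fold higher number from compound 1 to compound 3 (0.69 log units; beyond the scatter), concerns the aryl on the carbonyl carbon, not the aryl carried by the shared core. Compound 4 `COc1ccc(-c2cc(/C=C/C(=O)c3ccc(N)cc3)[nH]n2)cc1OC` differs from compound 1 as follows: hydrogen in place of methoxy on an aromatic carbon. The change sits ortho to a methoxy group and meta to a large group, on the ring attached to the core. Among the measured compounds shown here, no measured step touches that ring on its own; compound 2, at 3740 nM, carries a single methoxy on that ring but also differs from compound 1 in the carbonyl-side aryl, so its value bears only loosely. On that thin basis the expected step from compound 1 to compound 4 is a 1.3-fold higher number from compound 1 to compound 4 (0.10 log units; within the scatter), not beyond the scatter. Compound 4 is therefore estimated at 3500 nM, with a range from 1500 nM to 9000 nM.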

Compound 4, concentration for total growth inhibition: 5310 nM
Compound 4: the middle estimate sits 1.5-fold (0.18 log units) below what was measured, and the stated range covers the measured number.
By their numbers in this assay, from the lowest: compounds 1, 2 and 4 (each within the scatter of the next); then compound 3.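

In this assay, within the data shown here, this is the first change made on its own on the ring attached to the core: hydrogen in place of methoxy, ortho to a methoxy group and meta to a large group, gives a 1.9-fold higher number from compound 1 to compound 4 (0.29 log units; within the scatter). Among these compounds, with the 4-aminophenyl held on the carbonyl carbon, this methoxy can therefore go without a step beyond the scatter, and the only such step so far remains the carbonyl-side change, a 4.9-fold higher number from compound 1 to compound 3 (0.69 log units; beyond the scatter). No measurement here offers an explanation for the result.

Open, going by these compounds, is whether a hydroxy or an ethoxy at this position would move the number beyond the scatter. Also open, on these data alone, is whether the same change reads alike with the 3,4-dichlorophenyl of compound 3 on the carbonyl carbon, and what each remaining methoxy contributes on its own.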